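Inactive urea sulfonamides and a benzyl-for-catechol swap

The compounds below may be only part of what the source reports. "The series", "measured", "known", "first", "only" and "open" are said of these compounds alone.

Measured compounds, each reported only as a limit of a functional assay on HeLa cells (Homo sapiens) for inhibition, read by CCK-8 assay, with a stated time of 48 h; on this read-out lower numbers stand for stronger inhibition and higher numbers for weaker inhibition:
compound 1 `O=C(NCCNS(=O)(=O)c1ccc(-c2ccccc2Oc2ccc(O)c(O)c2)s1)Nc1cc(Cl)cc(Cl)c1`: > 20000 nM
compound 2 `O=C(NCCNS(=O)(=O)c1ccc(-c2ccccc2OCc2ccccc2)s1)Nc1cc(Cl)cc(Cl)c1`: > 20000 nM
compound 3 `O=C(NCCNS(=O)(=O)c1ccc(-c2ccccc2Oc2ccc(O)c(O)c2)s1)Nc1cc(C(F)(F)F)cc(C(F)(F)F)c1`: > 20000 nM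

In this assay compound 1 gives only a limit, > 20000 nM. Compound 2 likewise gives only a limit, > 20000 nM. Compound 3 too gives only a limit, > 20000 nM. The step that the two limits leave unreadable from compound 1 to compound 2 therefore cannot be sized; the change behind it is benzyl in place of 3,4-dihydroxyphenyl on an oxygen on an aromatic ring. How the core of compound 3 differs from that of compound 1 is not broken down here.

Compound 4 `O=C(NCCNS(=O)(=O)c1ccc(-c2ccccc2OCc2ccccc2)s1)Nc1cc(C(F)(F)F)cc(C(F)(F)F)c1` is not yet measured. It differs from compound 3 by benzyl in place of 3,4-dihydroxyphenyl on an oxygen on an aromatic ring, the same change as that from compound 1 to compound 2, at the same place. The expectation for compound 4 rests on the limit of > 20000 nM in this assay, at which 3 of the 3 values shown sit: with all three measured values sitting at that limit, the step that the limit leaves unreadable from compound 3 to compound 4 is expected to leave compound 4 at the limit as well. Compound 4 is thus estimated at 40000 nM, between 15000 nM and 150000 nM.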

Compound 4, half-maximal inhibitory concentration: 13500 nM
Estimate against measurement, compound 4: 3.0-fold (0.47 log units) above; measured number below the stated range.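

In this assay, for the compounds shown here, putting benzyl in place of 3,4-dihydroxyphenyl on the core of compound 3 gives an at least 1.4-fold lower number from compound 3 to compound 4 (0.17 log units; that floor lies within the scatter), and compound 4 is the only one of the four compounds with a number rather than a limit. On the other core, the same change leads to compound 2, which gives only a limit, > 20000 nM. The step on that core cannot be read, so the two steps cannot be compared, and the series shows neither that the change carries from one core to the other nor that it fails to; even on the core of compound 3, the floor of the step stays within the scatter.

The compounds shown leave open whether the number for compound 4 depends on the trifluoromethyl groups as well as on the benzyl. They also leave open how a smaller group such as methyl, or a benzyl carrying a carboxylic acid, would behave on that oxygen on either core.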